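The compounds below may be only part of what the source reports. "The series", "measured", "known", "first", "only" and "open" are said of these compounds alone.

Compound 1 `CC(=O)c1ccccc1NC(=O)N[C@@H](C)c1ccccc1` and compound 2 `CC(=O)c1cccc(NC(=O)N[C@H](C)c2ccccc2)c1` share the same atoms joined differently; how the two cores differ is not broken down here. In an ADME assay on the whole organism with Oryza sativa as the target, tested at 10 uM (on this read-out lower numbers stand for a stronger effect and higher numbers for a weaker effect at the one concentration tested), compound 1 gives 96%, and compound 2 gives 73%. Compound 3 `C[C@H](NC(=O)Nc1ccccc1F)c1ccccc1` arises from compound 1 by fluoro in place of acetyl on an aromatic carbon, and in this assay compound 3 gives 65%, so that a number 31 percentage points lower from compound 1 to compound 3 (beyond the scatter). The values of compound 2 and compound 3 lie within the scatter of each other.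

Compound 4 `C[C@@H](NC(=O)Nc1cccc(F)c1)c1ccccc1` has not yet been measured. It arises from compound 2 by fluoro in place of acetyl on an aromatic carbon, which is the same kind of change as that from compound 1 to compound 3, though the place differs: ortho to a large group in the earlier pair, meta to a large group here. Resting on a number 31 percentage points lower from compound 1 to compound 3 (beyond the scatter) as the only measured step of this kind, compound 4 is expected to show a number 25 percentage points lower from compound 2 to compound 4 (beyond the scatter) in this assay, somewhat softened for the uncertainty that the place is not the same. Compound 4 is therefore estimated at 48%, between 28% and 72%.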

Compound 4, a percentage reported as activity, at one concentration (the size of the read-out at that concentration, not a potency): 84%
The estimate for compound 4 lay 36 percentage points below the measured number; measured number outside the range, above it.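

In this assay, fluoro in place of acetyl on an aromatic carbon gives a number 11 percentage points higher from compound 2 to compound 4 (beyond the scatter). The change therefore does not carry over from the core of compound 1 to the core of compound 2 in this series, since the two steps run in opposite directions and differ in size: the same change on two cores in this assay, a number 31 percentage points lower (beyond the scatter) from compound 1 to compound 3 and a number 11 percentage points higher (beyond the scatter) from compound 2 to compound 4, 42 percentage points apart, beyond the scatter of two such steps. Within the data shown here, with only two pairs, this does not show whether the place of the change, meta to a large group in the later pair, accounts for the gap, and it gives no rule for other places or other cores.

The compounds shown leave open how a chloro group, a methoxy group or an amine would fare in place of acetyl on either core. They also leave open whether a longer chain there would follow the step seen on the core of compound 1 or the one seen on the core of compound 2.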